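The compounds below may be only part of what the source reports. "The series", "measured", "known", "first", "only" and "open" are said of these compounds alone.

Within the data shown here, compound 1 `C[C@H](NC(=O)c1c(Cc2ccc(C(C)(C)C)cc2)sc2c1CCOC2)c1ccc(C(=O)O)cc1` is one of three compounds measured in a functional assay on CHO/Galpha16 cells for antagonist activity at prostaglandin E2 receptor EP4 subtype (Homo sapiens), read by calcium flux, with a stated time of 15 min (on this read-out lower numbers stand for stronger inhibition and higher numbers for weaker inhibition), where compound 1 gives 9.5 nM. Compound 2 `O=C(O)c1ccc(C2(NC(=O)c3c(Cc4cccc(C(F)(F)F)c4)sc4c3CCOC4)CC2)cc1` gives 1 nM and compound 3 `COc1ccc2cc(C#Cc3sc4c(c3C(=O)N[C@@H](C)c3ccc(C(=O)O)cc3)CCOC4)ccc2c1` gives 27.2 nM. Compound 1 thus stands second highest of the three numbers: compound 3 lies nearer to it, with a number higher beyond the usual scatter, while compound 2 lies furthest away, with a number lower beyond the scatter. Compound 4 `COc1ccc(Cc2sc3c(c2C(=O)N[C@@H](C)c2ccc(C(=O)O)cc2)CCOC3)cc1` has not yet been measured. It differs from compound 1 in one place: methoxy in place of tert-butyl on an aromatic carbon. Among the measured compounds shown here, no measured pair shares this change, so the guide is thin; a modest weakening is expected, a 2.6-fold higher number from compound 1 to compound 4 (0.42 log units; beyond the scatter). The value of compound 4 is estimated at 25 nM, within a range from 8 nM to 80 nM.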

Compound 4, half-maximal inhibitory concentration: 2.1 nM
The estimate for compound 4 lay 12-fold (1.08 log units) above the measured number; measured number below the stated range.
By their numbers in this assay, from the lowest: compound 2; then compound 4; then compound 1; then compound 3.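

In this assay the change from 4-(tert-butyl)benzyl to 4-methoxybenzyl gives a 4.5-fold lower number from compound 1 to compound 4 (0.66 log units; beyond the scatter) and so shows that this position does not need the tert-butyl group: methoxy, with fewer heavy atoms and one hydrogen-bond acceptor, gives the lower number. The earlier compounds shown here offered no pair that varied this position. Nothing available here explains the drop. Still open, as far as these compounds go, is how a hydroxyl, a chlorine or a plain hydrogen on this carbon would compare, and whether methoxy would give a similar step in the setting of compound 2.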